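A few compounds are considered here, and "the series" means these few. Any claim that something is new, unique, unknown or untested is made for them only; others in the source may bear on it.

Working notes on the series. Compound 1 `Cc1ccccc1Nc1nc(Nc2ccccc2)ncc1Cl` and compound 2 `COc1ccc(CNc2nc(Nc3ccc(N4CCN(C)CC4)cn3)ncc2Cl)cc1` have been measured; compound 3 `CN1CCN(c2ccc(Nc3ncc(Cl)c(Nc4ccc(C(C)(C)C)cc4)n3)nc2)CC1` has not. In an ADME assay on L02 cells (Homo sapiens) for inhibition, read by CCK-8 assay, with a stated time of 48 h (on this read-out higher numbers stand for weaker inhibition of growth and lower numbers for stronger inhibition of growth), compound 1 gives > 100000 nM, which is a limit of the assay and not a number. In this assay, for the measured compounds named here, compound 2 gives 12900 nM, the only number so far in the set. The remaining entry is the limit of > 100000 nM in this assay, at which 1 of the 2 values shown sits. Going by the values given here, with one number and one limit, no measured step is available to set the scale of any change. Compound 3 differs from compound 2 by 4-(tert-butyl)phenyl in place of 4-methoxybenzyl on a nitrogen on an aromatic ring. Among the compounds with values here, no step of this kind has been measured here, so the expectation rests on the two values alone, and a move in either direction within the usual scatter, or only a little beyond it, is plausible. The expected step is a 1.2-fold higher number from compound 2 to compound 3 (0.07 log units; within the scatter). In this assay compound 3 is estimated at 15000 nM, within 4000 nM to 60000 nM, with some chance that only a limit is reported.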

Compound 3, concentration for 50% growth inhibition: 6070 nM
Compound 3: the middle estimate sits 2.5-fold (0.39 log units) above what was measured, within the range that was stated.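

In this assay, for the compounds shown here, the change to 4-(tert-butyl)phenyl in place of 4-methoxybenzyl on a nitrogen on an aromatic ring gives a 2.1-fold lower number from compound 2 to compound 3 (0.33 log units; beyond the scatter) as the first measured step. The position therefore accepts a change of group with only a modest shift, and the number falls even though the entering group has no hydrogen-bond acceptor, so the acceptor of 4-methoxybenzyl is not required to hold the read-out at the level of compound 2. Nothing measured here speaks to the cause of this step.

A single step cannot separate the loss of the methoxy oxygen from the gain of the tert-butyl group or from the change from benzyl to phenyl. Going by these compounds, whether a primary amine or a carboxylic acid on this aromatic ring would move the number in the same direction remains open.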